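The source may hold more compounds than are shown below. What is called first, only, known or untested is meant among the compounds shown, and "the series" means these compounds.

The measured compounds and their numbers:

Compound 1 `Brc1ccc(-c2cc(COc3ccccc3-c3nc4ccccc4s3)on2)cc1`: in a functional assay on MCF7 cells (Homo sapiens) for cytotoxicity, read by MTT assay, with a stated time of 24 h (a lower number here means a stronger inhibitor, a higher number a weaker inhibitor), compound 1 gives 20000 nM.
Compound 2 `Fc1ccccc1-c1cc(COc2ccccc2-c2nc3ccccc3s2)on1`: in this assay compound 2 gives 23900 nM.
Compound 3 `Clc1ccc(-c2cc(COc3ccccc3-c3nc4ccccc4s3)on2)cc1`: in this assay compound 3 gives 23800 nM.

All three share the same core and differ only in the aryl group carried on it. Compound 3 stands second highest of these three numbers, but the spread is tiny: a 1.2-fold higher number from compound 1 to compound 3 (0.08 log units; within the scatter) and a 1.0-fold lower number from compound 2 to compound 3 (0.00 log units; within the scatter). Within the scatter nothing separates the three, so none of them can be called stronger or weaker than another.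

Compound 4 `Cc1ccc(-c2cc(COc3ccccc3-c3nc4ccccc4s3)on2)cc1` has not yet been measured. Relative to compound 3, the change is methyl in place of chloro on an aromatic carbon.

Going by the values given here, two measured steps bear on this. The closest parallel is the swap of one halogen for another at the same position, which produced a 1.2-fold higher number from compound 1 to compound 3 (0.08 log units; within the scatter). Exchanging the whole aryl group, from compound 2 to compound 3, likewise gave a 1.0-fold lower number from compound 2 to compound 3 (0.00 log units; within the scatter). Among the compounds with values here, neither step involves a methyl group, so there is no direct precedent, but every change seen so far at this part of the molecule left the number within the scatter. The expectation is therefore no step beyond the scatter: a 1.1-fold lower number from compound 3 to compound 4 (0.03 log units; within the scatter). Compound 4 is estimated at 22000 nM, with an expected range from 10000 nM to 50000 nM.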

Compound 4, half-maximal inhibitory concentration: 27500 nM
Estimate against measurement, compound 4: 1.3-fold (0.10 log units) below; measured number inside the range.
By their numbers in this assay, from the lowest: compounds 1, 3, 2 and 4 (each within the scatter of the next).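

Going by these compounds alone, putting a methyl where compound 3 carries chloro, on the aromatic carbon para to a large group, gives a 1.2-fold higher number from compound 3 to compound 4 (0.06 log units; within the scatter) in this assay, so the first group at this position that is not a halogen also stays within the scatter. The comparisons with the other two aryl groups read the same way: a 1.2-fold higher number from compound 2 to compound 4 (0.06 log units; within the scatter) and a 1.4-fold higher number from compound 1 to compound 4 (0.14 log units; within the scatter) are both within the scatter as well, which means that 4-methylphenyl cannot be separated from 4-bromophenyl, 4-chlorophenyl or 2-fluorophenyl in this assay, and the four compounds form a single group with no ranking among them. Nothing measured alongside these numbers offers an explanation for this flat picture.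

The groups shown on this aryl ring are only halogens and a methyl, so it remains open whether an amine, a carboxylic acid or a longer chain such as butyl at the same place would give a step beyond the scatter. Going by these compounds, it is equally open how the number would respond to a change elsewhere in the molecule, in the shared core or in the link that joins the aryl-bearing part to it.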